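Benzyloxy in Place of Amino on the Double-Bonded Nitrogen

This account rests on a few compounds, and the source may have more. Where it says the series, first, only, none or still open, it means among the compounds named here.

Within the data shown here, compound 1 `N/N=C/c1c(N)ncnc1Oc1ccc(NC(=O)C2(C(=O)Nc3ccc(F)cc3)CC2)cc1F` gives 2.25 in a physicochemical assay for lipophilicity, using the shake flask method (on this read-out higher numbers stand for higher lipophilicity and lower numbers for lower lipophilicity), the lowest of the three numbers measured so far. Compound 2 `C#CCO/N=C/c1c(N)ncnc1Oc1ccc(NC(=O)C2(C(=O)Nc3ccc(F)cc3)CC2)cc1F` gives 3.34 in this assay, and compound 3 `CCOC(=O)CO/N=C/c1c(N)ncnc1Oc1ccc(NC(=O)C2(C(=O)Nc3ccc(F)cc3)CC2)cc1F` gives 3.15. The two measured replacements of the amino group on the double-bonded nitrogen both raised the read-out: a number 1.09 log units higher from compound 1 to compound 2 (beyond the scatter), and a number 0.90 log units higher from compound 1 to compound 3 (beyond the scatter). Between the two replacements themselves the difference is small: a number 0.19 log units lower from compound 2 to compound 3 (within the scatter).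

Compound 4 `Nc1ncnc(Oc2ccc(NC(=O)C3(C(=O)Nc4ccc(F)cc4)CC3)cc2F)c1/C=N/OCc1ccccc1` differs from compound 1 in one place: benzyloxy in place of amino on a double-bonded nitrogen. Both measured steps away from the amino group at this nitrogen bear on this change, and both were upward and beyond the scatter, so an upward step beyond the scatter is expected here as well, and the estimate places it as a number 2.05 log units higher from compound 1 to compound 4 (beyond the scatter). On this basis compound 4 is estimated at 4.3 in this assay, with a range from 3.7 to 4.9.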

Compound 4, partition coefficient: 4.45
The estimate for compound 4 lay 0.15 log units below the measured number; the range from low to high includes it.
By their numbers in this assay, from the lowest: compound 1; then compounds 3 and 2 (each within the scatter of the next); then compound 4.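

In this assay, benzyloxy gives the largest step seen so far away from the amino group on the double-bonded nitrogen (a number 2.20 log units higher from compound 1 to compound 4 (beyond the scatter)), so the propargyloxy and (ethoxycarbonyl)methoxy groups did not mark the upper end of the read-out at this position. Phenyl on the saturated chain carbon also separates from both earlier groups (a number 1.30 log units higher from compound 3 to compound 4 (beyond the scatter); a number 1.11 log units higher from compound 2 to compound 4 (beyond the scatter)), whereas ethoxycarbonyl and ethynyl had stayed within the scatter of each other. No available data explain the size of these steps.

Whether the rise follows the phenyl ring itself or simply the larger group remains open, since the compounds shown do not separate the two. Also open, going by these compounds, is what a longer chain ending in phenyl, or a benzyloxy group carrying an amine or a carboxylic acid, would give here.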